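The source may hold more compounds than are shown below. What is called first, only, known or untested is meant among the compounds shown, and "the series" means these compounds.

Measured compounds in a functional assay on CCRF-CEM cells for antagonist activity at C-X-C chemokine receptor type 4 (Homo sapiens), read by calcium flux, with stated times of 25 min and 90 s; a higher number here means a weaker inhibitor, a lower number a stronger inhibitor:
- compound 1 `CN(C[C@H]1Cc2c(cccc2N2CCN(C3CC3)CC2)CN1)[C@H]1CCCc2cccnc21`: 23.5 nM
- compound 2 `c1cnc2c(c1)CCC[C@@H]2N(CC1CC1)C[C@H]1Cc2c(cccc2N2CCNCC2)CN1`: 26.7 nM
- compound 3 `c1cnc2c(c1)CCC[C@@H]2N(CC1CCCCC1)C[C@H]1Cc2c(cccc2N2CCNCC2)CN1`: 715 nM

Compound 1 gives the lowest number of the three in this assay, but its nearest neighbour is compound 2, whose value sits within the scatter of that of compound 1, so the two cannot be ordered. Among the compounds with values here, compound 3 stands far apart: the only single-point step in the set, a 27-fold higher number from compound 2 to compound 3 (1.43 log units; beyond the scatter), shows that a large saturated ring in place of cyclopropyl on a saturated chain carbon bound to an amine nitrogen costs a great deal of potency.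

Compound 4 `CCN1CCN(c2cccc3c2C[C@H](CN(C)[C@H]2CCCc4cccnc42)NC3)CC1` differs from compound 1 at a different position: ethyl in place of cyclopropyl on an amine nitrogen in a ring. The change keeps the group on the piperazine nitrogen small and reduces it by one heavy atom rather than enlarging it. Within the data shown here, no measured step touches this nitrogen, and the step from compound 2 to compound 3 concerns a growth of ring size elsewhere in the molecule, so it bears on the present change only in showing that the series is sensitive to bulk near an amine nitrogen. For a small group swapped for a small group, a step of a 1.3-fold higher number from compound 1 to compound 4 (0.11 log units; within the scatter) is expected, most likely within the scatter, with no clear direction. Compound 4 is therefore estimated at 30 nM, with a range of 12 nM to 80 nM.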

Compound 4, half-maximal inhibitory concentration: 13.8 nM
Compound 4: the middle estimate sits 2.2-fold (0.34 log units) above what was measured; the range from low to high includes it.
By their numbers in this assay, from the lowest: compounds 4, 1 and 2 (each within the scatter of the next); then compound 3.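

In this assay, within the data shown here, ethyl in place of cyclopropyl on an amine nitrogen in a ring gives a 1.7-fold lower number from compound 1 to compound 4 (0.23 log units; within the scatter), the first measured step at this position. The two values cannot be ordered, so at this nitrogen ethyl, with 2 heavy atoms and no ring, serves as well as cyclopropyl, with 3 heavy atoms and a three-membered ring; the ring itself is not required here. The large step of a 27-fold higher number from compound 2 to compound 3 (1.43 log units; beyond the scatter) belongs to a different position, and nothing of that size appears for this exchange of two small groups.

The compounds shown leave open how far this nitrogen tolerates groups beyond these two, such as a longer chain like n-butyl, a benzyl group or a hydroxyethyl chain. They also leave open the effect of a plain hydrogen on this nitrogen with the methyl of compound 1 retained: compound 2 carries that hydrogen but also differs on the chain amine, and so gives no single-place comparison with compound 1 or compound 4.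

No measurement in hand offers an explanation for this result.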